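A few compounds are considered here, and "the series" means these few. Any claim that something is new, unique, unknown or untested is made for them only; others in the source may bear on it.

Measured compounds:
compound 1 `CC1(C)CC(=O)N(c2cnc(NCc3c(F)ccc4c3CCO4)n3cnnc23)C1` — 16 mL.min-1.g-1
compound 2 `Cc1ncccc1-c1cnc(NCc2c(F)ccc3c2CCO3)c2cn[nH]c(=O)c12` — 41 mL.min-1.g-1

In an ADME assay on microsomes from liver (Homo sapiens) for metabolic stability, read by LC-MS, using NADPH, with stated times of 5 min and 30 min, tested at 1 uM (a higher number here means faster removal of the compound, a lower number slower removal), compound 1 gives 16 mL.min-1.g-1, the lowest of the two numbers; compound 2 gives 41 mL.min-1.g-1, a gap that lies beyond the scatter. Compound 3 `O=C1CCCN1c1cnc(NCc2c(F)ccc3c2CCO3)n2cnnc12` has not been measured. It differs from compound 1 in one place: 2-oxopyrrolidin-1-yl in place of 4,4-dimethyl-2-oxopyrrolidin-1-yl on an aromatic carbon. No measured pair shows this change, so its effect is not known from the numbers shown. For this assay a small step is expected, a 1.1-fold lower number from compound 1 to compound 3 (0.06 log units; within the scatter), within the scatter. Compound 3 is estimated at 14 mL.min-1.g-1, with a range from 6 mL.min-1.g-1 to 32 mL.min-1.g-1.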

Compound 3, intrinsic clearance in microsomes: < 3 mL.min-1.g-1
Compound 3 ended at the assay's limit; the forecaster's own chance of this, stated with the estimate: 5%; at least 4.6-fold (0.66 log units) between middle value and limit.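

In this assay, 2-oxopyrrolidin-1-yl in place of 4,4-dimethyl-2-oxopyrrolidin-1-yl on this aromatic carbon gives an at least 5.3-fold lower number from compound 1 to compound 3 (0.72 log units; beyond the scatter). The value of compound 3 is a limit of the assay, not a number: the limit of < 3 mL.min-1.g-1 in this assay, at which 1 of the 3 values shown sits. Among the compounds shown here, this single-place pair is the first reading at this position, and it shows that a change confined to the lactam ring here can move the number beyond the scatter.

On these data alone, whether the same change would act alike on another core remains open. So does how a morpholine, an amine or an open-chain amide would read on this aromatic carbon.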